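The source may hold more compounds than are shown below. What is called first, only, known or untested is meant among the compounds shown, and "the series" means these compounds.

Measured so far in a functional assay on the whole organism (B cells) with Mus musculus as the target; a lower number here means a smaller maximal response, a higher number a larger maximal response:
- compound 1, `CCn1c(=O)n(C2OC(CO)[C@@H](O)[C@H]2O)c2nc(N)nc(O)c21`, gives 82%
- compound 2, `CC1(C)O[C@@H]2[C@H](O1)[C@@H](CO)O[C@H]2n1c(=O)n(C/C=C/c2ccccc2)c2c(O)nc(N)nc21`, gives 16%
- compound 3, `C=CCn1c(=O)n([C@@H]2O[C@H](CO)[C@H]3OC(C)(CCC(=O)OCC)O[C@H]32)c2nc(N)nc(O)c21`, gives 44%

Compound 1 stands highest of the three numbers. Its nearest neighbour is compound 3, whose value lies beyond the scatter below it, and compound 2 lies further down still, also beyond the scatter. No pair among these three differs in only one place, so none of these gaps can be read as a single structural step; compounds 2 and 3 carry several changes at once relative to compound 1.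

Compound 4, `Nc1nc(O)c2c(n1)n(C1OC(CO)[C@@H](O)[C@H]1O)c(=O)n2CC(O)CO`, has not been measured in this assay. It differs from compound 1 as follows: 1,2-dihydroxyethyl in place of methyl on a saturated chain carbon bound to an aromatic nitrogen. The rest of the structure is unchanged. Among the measured compounds shown here, with no single-point step among the measured compounds to calibrate against, the size of the step is open. The compounds with larger changes at the aromatic nitrogen, compound 2 at 16% and compound 3 at 44%, sit lower than compound 1, but those carry further differences too, so a modest loss at most, or none beyond the scatter, is expected. Compound 4 is expected to give about 70%, in the range 40% to 95%. The expected step is a number 12 percentage points lower from compound 1 to compound 4 (beyond the scatter).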

Compound 4, largest response reached (reported as maximal response), in percent of the reference or control that the assay uses: 136%
For compound 4 the middle estimate is 66 percentage points below the measured one; the whole stated range lies below it.
By their numbers in this assay, from the lowest: compound 2; then compound 3; then compound 1; then compound 4.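

In this assay, among the compounds shown here, methyl to 1,2-dihydroxyethyl on a saturated chain carbon bound to an aromatic nitrogen is the first single-place change that can be read, and it gives a number 54 percentage points higher from compound 1 to compound 4 (beyond the scatter) as a large step. This position therefore responds strongly to the change, and the added dihydroxy chain goes with a larger maximal response rather than a smaller one. Nothing available here explains the rise.

This one step cannot separate the contribution of the two hydroxyl groups from that of the added chain length; a plain propyl or a 2-hydroxyethyl group at this place would help to part them. As far as these compounds go, how an amine or a carboxylic acid at the same place would read in this assay also remains open.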